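From Pyrrolidine to Morpholine on a Thiocarbonyl Carbon

The compounds below may be only part of what the source reports. "The series", "measured", "known", "first", "only" and "open" are said of these compounds alone.

Measured compounds:
compound 1, `Cc1ccnc(/C(N)=N/NC(=S)N2CCCC2)c1`: 87.7%
compound 2, `Cc1cccc(/C(N)=N/NC(=S)N2CCCCC2)n1`: 54%
compound 3, `N/C(=N\NC(=S)N1CCCCCC1)c1ccccn1`: 84%

These three compounds were tested in a functional assay on MCF7 cells (Homo sapiens) for cytotoxicity, read by MTT assay, with a stated time of 72 h, tested at 100 uM; a lower number here means less inhibition of growth, a higher number more inhibition of growth at the concentration tested. Compound 1 gives the highest of the three numbers; compound 3 sits within the usual scatter of it, while compound 2 lies well below, beyond the scatter. Compound 4, `Cc1ccnc(/C(N)=N/NC(=S)N2CCOCC2)c1`, has not yet been measured in this assay. It differs from compound 1 in one place: morpholin-4-yl in place of pyrrolidin-1-yl on a thiocarbonyl carbon. Among the measured compounds shown here, no pair among the measured compounds shows this exact change, so its effect is not known from these data. A moderate fall in this assay seems the most likely outcome, though a result within the scatter cannot be excluded. The step expected is a number 15.7 percentage points lower from compound 1 to compound 4 (beyond the scatter). Compound 4 is therefore estimated at 72%, with a range from 40% to 92%.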

Compound 4, percent growth inhibition at one concentration: 12.8%
Compound 4: the middle estimate sits 59.2 percentage points above what was measured, and the stated range ends above it.
By their numbers in this assay, from the lowest: compound 4; then compound 2; then compounds 3 and 1 (each within the scatter of the next).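

In this assay, morpholin-4-yl in place of pyrrolidin-1-yl on a thiocarbonyl carbon gives a number 74.9 percentage points lower from compound 1 to compound 4 (beyond the scatter). This first single-change pair shows that growth inhibition at the concentration tested depends strongly on the group at this place. No measurement here accounts for the fall. The change enlarges the ring and adds an oxygen at once, so the compounds shown leave open which of the two matters. A group such as thiomorpholin-4-yl, with sulfur where morpholine has oxygen, remains an open case on the core of compound 1.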